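The source may report more compounds than this note shows. Statements on the series, on what has been measured and on what is new or still open speak of the compounds shown alone.

Measured so far:
compound 1 `CN1CCN(CCCNc2nc(-c3cccnc3)nc3c2CN(Cc2ccccc2)CC3)CC1`, 100000 nM
compound 2 `CN(C)CCN1CCN(c2nc(-c3ccncc3)nc3c2CN(Cc2ccccc2)CC3)CC1`, 100000 nM

Both compounds were run in an assay on cells with Cystic fibrosis transmembrane conductance regulator variant F508del (Homo sapiens) as the target, read by fluorescence, with stated times of 24 h and 30 min; a higher number here means that more compound is needed for the effect, a lower number that less compound is needed. Compound 1 gives 100000 nM. Compound 2 gives 100000 nM, which is level with compound 1 at the digits shown, so the two stand together within the scatter and no order between them can be stated.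

Compound 3 `CN1CCN(CCCNc2nc(-c3ccncc3)nc3c2CN(Cc2ccccc2)CC3)CC1` has not yet been measured. It is built from the same atoms as compound 2, joined differently: (3-(4-methylpiperazin-1-yl)propyl)amino in place of 4-(2-(dimethylamino)ethyl)piperazin-1-yl on an aromatic carbon. The group that enters is the same (3-(4-methylpiperazin-1-yl)propyl)amino group that compound 1 carries on its own core, while the pyridin-4-yl group of compound 2 is kept.

Within the data shown here, no step between measured compounds is available, so nothing points to a move of any size. The expectation for the step of no change at the digits printed from compound 2 to compound 3 (within the scatter) is therefore none beyond the scatter, because compound 1 with the entering group gives 100000 nM and compound 2 with the kept pyridin-4-yl group gives 100000 nM. Compound 3 is accordingly estimated at 100000 nM in this assay, with a range of 30000 nM to 200000 nM.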

Compound 3, half-maximal effective concentration: 100000 nM
Beside the measured number, compound 3's estimate shows no gap at the digits printed, within the range that was stated.
By their numbers in this assay, from the lowest: compounds 1, 2 and 3 (each within the scatter of the next).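

In this assay, (3-(4-methylpiperazin-1-yl)propyl)amino in place of 4-(2-(dimethylamino)ethyl)piperazin-1-yl on this aromatic carbon gives the first step read at this position (no change at the digits printed from compound 2 to compound 3 (within the scatter)), so the exchange of two groups of equal heavy-atom count, with the entering group carrying 1 hydrogen-bond donor and the leaving group 0, does not separate the two compounds. Among these compounds, the second step isolates the pyridine attachment for the first time: pyridin-4-yl in place of pyridin-3-yl gives (no change at the digits printed from compound 1 to compound 3 (within the scatter)), so this change also does not separate its two compounds. No supporting data bear on either result.

With only these two changes read, each around compound 3, neither the position of the amine side chain nor the pyridine attachment has yet been seen to shift the read-out from the level of compound 3 (100000 nM). Open, going by these compounds, is whether a morpholin-4-yl group at the position of the side chain, or a phenyl group in place of the pyridin-4-yl group, would give a value apart from that level.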